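This account rests on a few compounds, and the source may have more. Where it says the series, first, only, none or still open, it means among the compounds named here.

Measured so far in a functional assay on cells (leukaemia cell line, Homo sapiens) for inhibition, read by sulforhodamine B assay, with a stated time of 48 h; on this read-out lower numbers stand for stronger inhibition of growth and higher numbers for weaker inhibition of growth:
- compound 1 (`O=S(=O)(Nc1ccc(Cl)cc1Cl)c1ccc(-c2cnc(C3CC3)o2)cc1`) gives 74500 nM
- compound 2 (`O=S(=O)(Nc1ccccc1Cl)c1ccc(-c2cnc(C3CC3)o2)cc1`) gives 49700 nM
- compound 3 (`O=S(=O)(Nc1ccc(Br)c(Cl)c1)c1ccc(-c2cnc(C3CC3)o2)cc1`) gives 70300 nM

Compound 2 does not stand apart from the other two values. Both steps that touch it (a 1.5-fold lower number from compound 1 to compound 2 (0.18 log units; within the scatter)) and (a 1.4-fold higher number from compound 2 to compound 3 (0.15 log units; within the scatter)) stay within the scatter, as does the remaining step (a 1.1-fold lower number from compound 1 to compound 3 (0.03 log units; within the scatter)).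

Compound 4 (`Cc1ccc(NS(=O)(=O)c2ccc(-c3cnc(C4CC4)o3)cc2)cc1C`) has not yet been measured. Its change from compound 2 lies on a sulfonamide nitrogen, with 3,4-dimethylphenyl in place of 2-chlorophenyl (3,4-dimethylphenyl in place of 2-chlorophenyl on a sulfonamide nitrogen). The nearest measured precedent replaces the same 2-chlorophenyl on the same nitrogen with 4-bromo-3-chlorophenyl, the step to compound 3 (a 1.4-fold higher number from compound 2 to compound 3 (0.15 log units; within the scatter)). The step that removes a chloro from compound 1 (a 1.5-fold lower number from compound 1 to compound 2 (0.18 log units; within the scatter)) is likewise small. All three aryl groups measured on this nitrogen therefore give values within the scatter of one another. Within the data shown here, no measured compound carries methyl groups on this ring, however, so the precedent covers chloro and bromo only, and the range is kept wide. No step beyond the scatter is expected in this assay, and no direction is favoured (a 1.1-fold higher number from compound 2 to compound 4 (0.04 log units; within the scatter)). For compound 4 the estimate is 55000 nM with an expected range from 25000 nM to 100000 nM in this read-out.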

Compound 4, concentration for total growth inhibition: > 100000 nM
Compound 4: only a limit was reported; the forecaster's own chance of this, stated with the estimate: 15%; at least 1.8-fold (0.25 log units) between middle value and limit.
By their numbers in this assay, from the lowest: compounds 2, 3 and 1 (each within the scatter of the next). At a limit, above all of these: compound 4.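

In this assay, compound 4 is the first compound on this sulfonamide nitrogen reported only as a limit rather than a number: the limit of > 100000 nM in this assay, at which 1 of the 4 values shown sits.

Read against the other compounds, the result gives only floors: an at least 2.0-fold higher number from compound 2 to compound 4 (0.30 log units; that floor lies within the scatter), an at least 1.4-fold higher number from compound 3 to compound 4 (0.15 log units; that floor lies within the scatter) and an at least 1.3-fold higher number from compound 1 to compound 4 (0.12 log units; that floor lies within the scatter). Each floor lies within the scatter, so none of these steps is shown to exceed it, although each could be larger. Among these compounds, the change to 3,4-dimethylphenyl is the first on this nitrogen to bring an aryl group without chlorine or bromine, and it is the only one of the four groups without a numerical result, but a single compound sets no pattern for halogen against methyl.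

From the compounds shown here alone, the actual value of compound 4 remains open, and so does whether any group on this nitrogen can move the read-out beyond the scatter. Also open, going by these compounds, is whether a single methyl, a methoxy or an amine on this aromatic ring, or a longer chain in place of the ring, would give a number in this assay.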